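Swapping a fluorobenzyl for propyl on a sulfur

The source may hold more compounds than are shown below. What is called first, only, known or untested is meant among the compounds shown, and "the series" means these compounds.

Compound 1 `C[C@@H]1CCN(c2cc(-c3ccccc3)nc3ncnn23)C[C@@H]1N(C)c1ncnc2[nH]ccc12` — in a functional assay on HGC-27 cells (Homo sapiens) for inhibition, read by MTT assay, with a stated time of 72 h (on this read-out higher numbers stand for weaker inhibition and lower numbers for stronger inhibition), compound 1 gives > 100000 nM, which is a limit of the assay rather than a number (the limit of > 100000 nM in this assay, at which 1 of the 3 values shown sits).
Compound 2 `Cc1cc(N2CC[C@@H](C)[C@@H](N(C)c3ncnc4[nH]ccc34)C2)n2nc(SCc3ccc(F)cc3)nc2n1` — compound 2 gives 26000 nM.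
Compound 3 `Cc1cc(N2CC[C@@H](C)[C@@H](N(C)c3ncnc4[nH]ccc34)C2)n2nc(SCc3cc(Cl)ccc3Cl)nc2n1` — compound 3 gives 19200 nM.

Compound 2 stands at the top of the two numbers shown, but the step of a 1.4-fold lower number from compound 2 to compound 3 (0.13 log units; within the scatter) lies within the scatter, so compound 2 and compound 3 cannot be told apart. Among the measured compounds shown here, that step, 2,5-dichlorophenyl in place of 4-fluorophenyl on a saturated chain carbon bound to a sulfur, is the only measured change at this position.

Compound 4 `CCCSc1nc2nc(C)cc(N3CC[C@@H](C)[C@@H](N(C)c4ncnc5[nH]ccc45)C3)n2n1` differs from compound 2 by ethyl in place of 4-fluorophenyl on a saturated chain carbon bound to a sulfur. For the measured compounds named here, the one measured step at this place exchanged one aromatic ring for another and stayed within the scatter; no measured step removes the ring for a short chain, so that step gives only weak guidance. A change of about the same size, or a modest rise, is expected. Compound 4 is estimated at 40000 nM, between 15000 nM and 100000 nM, which is expected to be a step of a 1.5-fold higher number from compound 2 to compound 4 (0.19 log units; within the scatter).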

Compound 4, half-maximal inhibitory concentration: 20900 nM
Compound 4: the middle estimate sits 1.9-fold (0.28 log units) above what was measured; the range from low to high includes it.
By their numbers in this assay, from the lowest: compounds 3, 4 and 2 (each within the scatter of the next). At a limit, above all of these: compound 1.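

Among the compounds shown here, what compound 4 adds is a first look at losing the aromatic ring altogether, not just exchanging one ring for another. In this assay, both a 1.2-fold lower number from compound 2 to compound 4 (0.09 log units; within the scatter) and a 1.1-fold higher number from compound 3 to compound 4 (0.04 log units; within the scatter) are small enough that the three compounds cannot be told apart. Among these three compounds, then, an aromatic ring on this sulfur is not needed to keep the value, and a plain propyl group serves as well as 4-fluorobenzyl or the dichlorinated benzyl; nothing shown explains why.

The compounds shown leave open whether a longer chain, an amine or a carboxylic acid on the sulfur would move the number beyond the scatter. They also leave open what happens when the sulfur itself gives way to an oxygen or a nitrogen.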